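Dropping a Chloro Group From Compound 1

The source may report more compounds than this note shows. Statements on the series, on what has been measured and on what is new or still open speak of the compounds shown alone.

Compound 1, `Cc1cccc(Cl)c1NC(=O)CN1CCN(c2nnc(Cc3ccncc3)c3ccccc23)CC1`, was tested in a functional assay on A549 cells (Homo sapiens) for cytotoxicity, read by MTT assay, with a stated time of 72 h (a higher number here means a weaker inhibitor, a lower number a stronger inhibitor), where compound 1 gives 7190 nM. That is the highest of the two numbers recorded so far. Going by the values given here, the other, compound 2, `O=C(CN1CCN(c2nnc(Cc3ccccc3)c3ccccc23)CC1)Nc1ccc(F)c(C(F)(F)F)c1`, gives 2480 nM in this assay; the two compounds differ in several places at once, so their values show only that compound 2 sits at the lower number, with a gap beyond the usual scatter.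

Compound 3, `Cc1ccccc1NC(=O)CN1CCN(c2nnc(Cc3ccncc3)c3ccccc23)CC1`, has not yet been measured. It differs from compound 1 in one place: hydrogen in place of chloro on an aromatic carbon. The (2-chloro-6-methylphenyl)carbamoyl of compound 1 becomes a (2-methylphenyl)carbamoyl. Among the compounds with values here, no measured pair of this kind exists here. The expected step is a 1.3-fold higher number from compound 1 to compound 3 (0.12 log units; within the scatter), small and most likely toward a somewhat higher number, though possibly no change beyond the scatter. Compound 3 is therefore estimated to give 9500 nM in this assay, within a range from 3600 nM to 25000 nM.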

Compound 3, half-maximal inhibitory concentration: 43100 nM
Estimate against measurement, compound 3: 4.5-fold (0.66 log units) below; measured number outside the range, above it.
By their numbers in this assay, from the lowest: compound 2; then compound 1; then compound 3.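

In this assay, going by these compounds alone, replacing the chloro with hydrogen on the aromatic ring of the anilide gives a 6.0-fold higher number from compound 1 to compound 3 (0.78 log units; beyond the scatter) and is the first change in a single place that can be read here. Since everything else in compound 1 stays the same, the weaker inhibition of compound 3 goes with the loss of this one chloro, so this aromatic carbon is not indifferent to substitution. Nothing available explains why a single chlorine carries a step of this size.

As far as these compounds go, whether bromo, methoxy or an amine on this same carbon would keep the number of compound 1, lower it further or behave like hydrogen remains open. Also open, from the compounds shown here alone, is whether removing the methyl group of the 2-chloro-6-methylphenyl would give a step of similar size.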